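A few compounds are considered here, and "the series" means these few. Any claim that something is new, unique, unknown or untested is made for them only; others in the source may bear on it.

Measured compounds:
compound 1 `C=C1[C@H](OC(C)=O)C[C@@H](OC(C)=O)C(C)(C)/C=C/[C@@H](C)C(=O)[C@@]2(OC(C)=O)C[C@@](C)(OC(C)=O)[C@H](OC(C)=O)[C@@H]2[C@H]1OC(C)=O`: 29.9%
compound 2 `CC(=O)O[C@H]1[C@H]2OC(=O)CC[C@](O)([C@@H]1OCC(C)C)[C@H](OC(C)=O)[C@H]1[C@@H](OC(C)=O)[C@](C)(OC(C)=O)C[C@]1(OC(C)=O)C(=O)[C@H](C)[C@H]1O[C@@H]1C2(C)C`: 33%
compound 3 `C=C1[C@H](OC(C)=O)CC(=O)C(C)(C)/C=C/[C@@H](C)C(=O)[C@@]2(OC(C)=O)C[C@@](C)(OC(C)=O)[C@H](OC(C)=O)[C@@H]2[C@H]1OC(C)=O`: 35%

All three were tested in a functional assay on Ishikawa cells (Homo sapiens) for inhibition, read by MTT assay, with a stated time of 72 h, tested at 30 ug/mL; on this read-out higher numbers stand for more inhibition of growth at the one concentration tested and lower numbers for less inhibition of growth. Compound 1, at 29.9%, cannot be separated from the other two, since its gaps to compound 2 and to compound 3 both lie within the usual scatter. Among the measured compounds shown here, no measured pair differs in one place only, so there is no measured step to carry over.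

The next compound is compound 4 `C=C1[C@H](OC(C)=O)C[C@@H](OC(=O)c2cccnc2)C(C)(C)/C=C/[C@@H](C)C(=O)[C@@]2(OC(C)=O)C[C@@](C)(OC(C)=O)[C@H](OC(C)=O)[C@@H]2[C@H]1OC(C)=O`, which keeps the core of compound 1 and changes one ester: pyridin-3-yl in place of methyl on a carbonyl carbon. Put another way, acetoxy gives way to ((pyridin-3-yl)carbonyl)oxy.

The expectation in this assay is of no step beyond the scatter, in either direction. It rests only on the three measured values: compound 1 at 29.9%, compound 2 at 33% and compound 3 at 35%. None of these compounds carries the entering group, so the range is kept wide. The estimated step of a number 3.1 percentage points higher from compound 1 to compound 4 (within the scatter) is expected to stay within the scatter. Compound 4 is expected at 33%, with an estimated range of 15% to 52%.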

Compound 4, percent growth inhibition at one concentration: 13.9%
Estimate against measurement, compound 4: 19.1 percentage points above; measured number outside the range, below it.
By their numbers in this assay, from the lowest: compound 4; then compounds 1, 2 and 3 (each within the scatter of the next).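

In this assay, among the compounds shown here, the change of pyridin-3-yl in place of methyl on a carbonyl carbon gives the first single-place step, with a number 16 percentage points lower from compound 1 to compound 4 (beyond the scatter). For the compounds shown here, this acetoxy on the core of compound 1 is therefore not a silent position: exchanging it for ((pyridin-3-yl)carbonyl)oxy lowers growth inhibition at the one concentration tested, something the earlier compounds could not show, as no pair among them differs in one place only. No measurement at hand bears on the reason for this step.

The step leaves open whether the fall goes with the ring nitrogen, with the aromatic ring itself or with the larger ester as a whole, and a benzoyl ester, a pyridin-4-yl carbonyl ester and a simple longer chain such as propanoyl would begin to separate these readings. Also open, from the compounds shown here alone, is whether the same exchange at any of the other acetoxy groups on the shared core would give a similar step, or whether this position is particular in that respect.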